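Swapping One Group on an Amine Nitrogen

The source may hold more compounds than are shown below. What is called first, only, known or untested is meant among the compounds shown, and "the series" means these compounds.

In a functional assay on HT-29 cells (Homo sapiens) for inhibition, read by CellTiter-Glo, with a stated time of 72 h (a lower number here means that less compound is tolerated, a higher number that more compound is tolerated), compound 3 `CC1=C(CC(=O)N(C)CCN(C)C(=O)[C@@H](N)C(C)C)c2cc(F)ccc2/C1=C\c1ccc([S+](C)[O-])cc1` gives 30200 nM. Compound 2 `COC(=O)[C@H](C)NC(=O)CC1=C(C)/C(=C/c2ccc(SC)cc2)c2ccc(F)cc21` gives 23900 nM, within the scatter of compound 3. Compound 1 `CC1=C(CC(=O)N2CCN(CCCN(C)C)CC2)c2cc(F)ccc2/C1=C\c1nc2ccccc2s1` gives 1620 nM, lower than compound 3 by more than the scatter. Compound 4 `CC1=C(CC(=O)N(C)CCN(C)S(=O)(=O)c2ccc(C)cc2)c2cc(F)ccc2/C1=C\c1ccc([S+](C)[O-])cc1` carries (4-methylphenyl)sulfonyl in place of (1-amino-2-methylpropyl)carbonyl on an amine nitrogen. Within the data shown here, no measured pair shows this change, so any forecast is uncertain. The closest guide is compound 2 at 23900 nM. Its structure differs from that of compound 3, and its value lies within the scatter of compound 3. In this assay, the expected change is small, with an estimated 1.5-fold lower number from compound 3 to compound 4 (0.18 log units; within the scatter), within the scatter. For compound 4, the estimated value is 20000 nM, with an expected range of 7000 nM to 50000 nM.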

Compound 4, half-maximal cytotoxic concentration: 6180 nM
The estimate for compound 4 lay 3.2-fold (0.51 log units) above the measured number, and the stated range ends above it.
By their numbers in this assay, from the lowest: compound 1; then compound 4; then compounds 2 and 3 (each within the scatter of the next).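

In this assay, among these compounds, the first direct comparison at this amine nitrogen gives a 4.9-fold lower number from compound 3 to compound 4 (0.69 log units; beyond the scatter) when (4-methylphenyl)sulfonyl replaces (1-amino-2-methylpropyl)carbonyl. The group on this nitrogen therefore affects how much compound the cells tolerate, even with the rest of the structure unchanged. Nothing measured here explains the change. As far as these compounds go, the swap alters several features at once, including the aromatic ring, the sulfonyl and the hydrogen-bond donor, so the responsible feature remains unknown. A benzoyl or methylsulfonyl group on the same nitrogen could help separate these features.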